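Shrinking the Ring on the Shared Core

A few compounds are considered here, and "the series" means these few. Any claim that something is new, unique, unknown or untested is made for them only; others in the source may bear on it.

Compound 2 `CC1CCC(Oc2cccc3ccc(N)nc23)C1` is one of three compounds that share a core and differ only in the group carried on an oxygen on an aromatic ring. In an assay on cells with melanin-concentrating hormone receptor 1 (Homo sapiens) as the target, read by radioligand binding (a lower number here means a stronger inhibitor, a higher number a weaker inhibitor), compound 2 gives 823 nM, the highest of the two numbers measured here. Compound 3 `CCCC(C)Oc1cccc2ccc(N)nc12` gives 105 nM; a 7.8-fold lower number from compound 2 to compound 3 (0.89 log units; beyond the scatter). Compound 1 `COCCOCCOc1cccc2ccc(N)nc12` reaches only a limit of the assay, > 2000 nM, not a number. Compound 4 `CC1CC1COc1cccc2ccc(N)nc12` carries (2-methylcyclopropyl)methyl in place of 3-methylcyclopentyl on an oxygen on an aromatic ring. For the measured compounds named here, only the step to compound 3 bears on this change, and it showed that leaving the five-membered ring for a smaller group lowered the number. Compound 4 keeps a ring, though a three-membered one, so a more modest gain is expected: a 2.4-fold lower number from compound 2 to compound 4 (0.37 log units; beyond the scatter). Compound 4 is therefore estimated at 350 nM, most likely between 100 nM and 1200 nM.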

Compound 4, half-maximal inhibitory concentration: 1640 nM
Compound 4: middle estimate off by 4.7-fold (0.67 log units), on the low side; measured number outside the range, above it.
By their numbers in this assay, from the lowest: compound 3; then compounds 2 and 4 (each within the scatter of the next). At a limit, above all of these: compound 1.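

Replacing 3-methylcyclopentyl with (2-methylcyclopropyl)methyl gives a 2.0-fold higher number from compound 2 to compound 4 (0.30 log units; within the scatter) and the size of the ring made no clear difference in this pair. The ring-free 1-methylbutyl stands apart from this ring-bearing group, with a 16-fold higher number from compound 3 to compound 4 (1.19 log units; beyond the scatter). Compound 1 also carries no ring, yet it gives only a limit of the assay, not a number. The step can be stated only as a floor, as an at least 1.2-fold lower number from compound 1 to compound 4 (0.08 log units; that floor lies within the scatter) shows: the limit of > 2000 nM in this assay, at which 1 of the 4 values shown sits.

On these data alone, whether the branch in 1-methylbutyl or the absence of a ring matters more remains open. So does how a longer branched chain or a chain ending in an amine would behave.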